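The source may report more compounds than this note shows. Statements on the series, on what has been measured and on what is new or still open speak of the compounds shown alone.

For the measured compounds named here, compound 2 `O=C(O)Cc1sc(Cc2ccccc2)nc1-c1ccc(F)cc1` holds the lowest of the two numbers so far in an in vitro assay on COS-7 cells for displacement of a labelled ligand from prostaglandin D2 receptor 2 (Homo sapiens) (a lower number here means a stronger inhibitor, a higher number a weaker inhibitor), where compound 2 gives 140 nM; its only neighbour, compound 1 `O=C(O)Cc1sc(-c2ccccc2)nc1-c1ccc(F)cc1`, gives 860 nM in this assay, and the step of a 6.1-fold lower number from compound 1 to compound 2 (0.79 log units; beyond the scatter) came with benzyl in place of phenyl. Compound 3 `O=C(O)Cc1sc(Cc2ccccc2Br)nc1-c1ccc(F)cc1` differs from compound 2 by bromo in place of hydrogen on an aromatic carbon. Going by the values given here, no measured step involves a bromo group, so nothing among the measured compounds bears on this change directly, and no step beyond the scatter is expected in this assay. Compound 3 is therefore estimated at 140 nM, within 50 nM to 400 nM. The step expected on this basis is no change at the digits printed from compound 2 to compound 3 (within the scatter).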

Compound 3, half-maximal inhibitory concentration: 700 nM
Estimate against measurement, compound 3: 5.0-fold (0.70 log units) below; measured number outside the range, above it.
By their numbers in this assay, from the lowest: compound 2; then compounds 3 and 1 (each within the scatter of the next).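

In this assay the ring of the benzyl group proves sensitive to one added atom: bromo in place of hydrogen, ortho to a large group, gives a 5.0-fold higher number from compound 2 to compound 3 (0.70 log units; beyond the scatter) and so takes back the gain that benzyl brought. Setting 2-bromobenzyl against phenyl gives a 1.2-fold lower number from compound 1 to compound 3 (0.09 log units; within the scatter) and leaves nothing of that gain. Nothing at hand explains what the bromo costs. On these data alone, whether fluoro, methyl or methoxy on this carbon would give a step of the same size stays open, as does the effect of bromo on the other carbons of that ring.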